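A few compounds are considered here, and "the series" means these few. Any claim that something is new, unique, unknown or untested is made for them only; others in the source may bear on it.

Measured compounds in an ADME assay on HFF cells (Homo sapiens) for cytotoxicity, with a stated time of 8 days; a lower number here means that less compound is tolerated, a higher number that more compound is tolerated:
compound 1, `C=CCOc1nc(N)nc2c1ncn2/C=C1/CC1(CO)CO`: > 300000 nM, a limit of the assay
compound 2, `Nc1nc(NCc2ccccc2)c2ncn(/C=C3/CC3(CO)CO)c2n1`: > 300000 nM, a limit of the assay
compound 3, `CCCNc1nc(N)nc2c1ncn2/C=C1/CC1(CO)CO`: > 300000 nM, a limit of the assay

Compound 1 stands only at a limit in this assay, not at a number. Compounds 2 and 3 stand at the same limit, so that (the limit of > 300000 nM in this assay, at which 3 of the 3 values shown sit). The steps among the three, a step that the two limits leave unreadable from compound 1 to compound 2, a step that the two limits leave unreadable from compound 1 to compound 3 and a step that the two limits leave unreadable from compound 2 to compound 3, cannot be sized from two limits.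

Compound 4, `CC(C)Sc1nc(N)nc2c1ncn2/C=C1/CC1(CO)CO`, is to be measured in this assay. It differs from compound 1 by isopropylsulfanyl in place of allyloxy on an aromatic carbon. The measured steps that bear on this change are the ones from compound 1 to compound 2 and from compound 1 to compound 3, each a replacement of the allyloxy group on the same aromatic carbon; both are unreadable and set no size. Since every measured compound sits at the limit whatever group stands there, no step beyond the scatter is expected for compound 4, and the expected step is a number no higher from compound 1 to compound 4 (the limit leaves the size open). Compound 4 is therefore estimated at 300000 nM in this assay, most likely reported again only as a limit.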

Compound 4, half-maximal cytotoxic concentration: > 300000 nM
Compound 4 was reported as a limit (the forecaster's own chance of this, stated with the estimate: 85%); the middle value sits exactly at the limit.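

In this assay, no new step can be read between compound 4 and compound 1, compound 2 or compound 3, as each pair consists of two limits: the limit of > 300000 nM in this assay, at which 4 of the 4 values shown sit.

The compounds shown leave open how far the cytotoxic concentration of any of them lies beyond that limit, and whether any group at this place on the shared core gives a value short of it.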